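Swapping the aryl group on a thiophene core for pyrazole

The source may hold more compounds than are shown below. What is called first, only, known or untested is meant among the compounds shown, and "the series" means these compounds.

Measured so far, in an assay on CHO cells for displacement of a labelled ligand from adenosine receptor A3 (Homo sapiens), read by scintillation counting, tested at 10 uM; on this read-out lower numbers stand for less inhibition and higher numbers for more inhibition at the one concentration tested (going by the name of the read-out):
compound 1 `CC(C)(C)Cc1c(-c2ccoc2)sc(N)c1C(=O)c1ccc(Cl)cc1`: 1%
compound 2 `CC(C)(C)Cc1c(/C=C/c2ccc(Cl)cc2)sc(N)c1C(=O)c1ccc(Cl)cc1`: 11%
compound 3 `COc1ccccc1-c1sc(N)c(C(=O)c2ccc(Cl)cc2)c1CC(C)(C)C`: 1%

Compound 3 stands level with compound 1 at the digits shown, and these two together are the lowest of the three numbers; compound 2 sits a little higher, though still within the scatter of either. The inhibition in this assay is thus low for all three compounds.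

Compound 4 `CC(C)(C)Cc1c(-c2cn[nH]c2)sc(N)c1C(=O)c1ccc(Cl)cc1` is the next step. Its change: 1H-pyrazol-4-yl in place of 2-methoxyphenyl on an aromatic carbon. For the measured compounds named here, the steps that bear on it are no change at the digits printed from compound 1 to compound 3 (within the scatter) and a number 10 percentage points lower from compound 2 to compound 3 (within the scatter), both within the scatter; a step of similar size, or none beyond the scatter, is therefore expected here, a number 2 percentage points higher from compound 3 to compound 4 (within the scatter). For compound 4 the expected value is 3%, within the range -8% to 15%.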

Compound 4, a percentage reported as inhibition, at one concentration (the size of the read-out at that concentration, not a potency): 1%
Compound 4: the middle estimate sits 2 percentage points above what was measured; the measured number falls inside the stated range.
By their numbers in this assay, from the lowest: compounds 1, 3, 4 and 2 (each within the scatter of the next).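

In this assay, 1H-pyrazol-4-yl brings a hydrogen-bond donor and fewer heavy atoms than 2-methoxyphenyl on the carbon next to the ring sulfur, and the result is no change at the digits printed from compound 3 to compound 4 (within the scatter). The other two comparisons give no change at the digits printed from compound 1 to compound 4 (within the scatter) and a number 10 percentage points lower from compound 2 to compound 4 (within the scatter), so this new kind of ring separates itself from none of the earlier groups. No supporting evidence is available to explain these numbers. As far as these compounds go, it remains open whether an amine or a carboxylic acid on this carbon would give more inhibition. A longer chain in place of the neopentyl group is equally untested here.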